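Swapping the benzofuran acyl group for a sorbyl-type chain

A few compounds are considered here, and "the series" means these few. Any claim that something is new, unique, unknown or untested is made for them only; others in the source may bear on it.

Compound 2 `CCCCCCCCCCCCCCNC(=O)[C@@H](NC(=O)c1cc2ccccc2o1)[C@@H](C)O` is one of two close relatives tested in a functional assay on A-431 cells (Homo sapiens) for cytotoxicity, read by MTT assay, with a stated time of 48 h; a lower number here means a stronger inhibitor, a higher number a weaker inhibitor. Compound 2 gives 20100 nM, and compound 1 `CCCCCCCCCCCCNC(=O)[C@@H](NC(=O)c1cc2ccccc2o1)[C@@H](C)O` gives 20000 nM. For the measured compounds named here, the only measured step, a 1.0-fold higher number from compound 1 to compound 2 (0.00 log units; within the scatter), lengthens the alkyl chain and leaves the number unchanged, so compound 2 stands at the higher of two values that cannot be told apart.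

Compound 3 `C/C=C/C=C/C(=O)N[C@H](C(=O)NCCCCCCCCCCCCCC)[C@@H](C)O` changes a different part of the molecule: penta-1,3-dien-1-yl in place of 1-benzofuran-2-yl on a carbonyl carbon. Going by the values given here, no measured step touches this acyl group, so the earlier step gives no guide to its effect, and the two compounds measured so far only show that the amide chain end tolerates change. With no evidence either way, compound 3 is expected to sit near its parent, with the step of a 1.2-fold higher number from compound 2 to compound 3 (0.09 log units; within the scatter) estimated as within the scatter. The estimate for compound 3 in this assay is 25000 nM, within a range from 8000 nM to 80000 nM.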

Compound 3, half-maximal inhibitory concentration: > 200000 nM
Compound 3 ended at the assay's limit; the forecaster's own chance of this, stated with the estimate: 30%; middle value at least 8.0-fold (0.90 log units) away from the limit.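

The acyl group turns out to matter far more than the chain end. In this assay, putting penta-1,3-dien-1-yl in place of 1-benzofuran-2-yl on the carbonyl carbon gives an at least 9.9-fold higher number from compound 2 to compound 3 (0.99 log units; beyond the scatter), whereas lengthening the alkyl chain gave a 1.0-fold higher number from compound 1 to compound 2 (0.00 log units; within the scatter). The value of compound 3 is a limit of the assay and not a number, so the full size of this step cannot be read: the limit of > 200000 nM in this assay, at which 1 of the 3 values shown sits.

For the compounds shown here, with only this one change at the carbonyl carbon, the result cannot separate the loss of the aromatic rings from the change in the size of the group or from the arrival of the two double bonds. A phenyl or a saturated pentyl group at the same place would be needed to tell these apart.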